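A few compounds are considered here, and "the series" means these few. Any claim that something is new, unique, unknown or untested is made for them only; others in the source may bear on it.

Compound 1 `CC(=O)c1ccc2c(c1)nc(-c1ccc(C(F)(F)F)cc1)n2C1CCCCC1` and compound 2 `COc1ccc(-c2nc3cc(C(C)=O)ccc3n2C2CCCCC2)cc1` share one core and differ only by methoxy in place of trifluoromethyl on an aromatic carbon. In an ADME assay on MT4 cells (Homo sapiens) for cytotoxicity, read by MTT assay, with a stated time of 96 h (a higher number here means that more compound is tolerated, a lower number that less compound is tolerated), compound 1 gives 41000 nM and compound 2 gives 27000 nM, so that change made a 1.5-fold lower number from compound 1 to compound 2 (0.18 log units; within the scatter). Compound 3 `C/C(=N\NC(N)=S)c1ccc2c(c1)nc(-c1ccc(C(F)(F)F)cc1)n2C1CCCCC1` differs from compound 1 by a group of 7 heavy atoms (3 carbon, 3 nitrogen, 1 sulfur; no ring) in place of a group of 3 heavy atoms (2 carbon, 1 oxygen; no ring), on an aromatic carbon; in this assay compound 3 gives 30000 nM, a step of a 1.4-fold lower number from compound 1 to compound 3 (0.14 log units; within the scatter). Compound 4 `COc1ccc(-c2nc3cc(/C(C)=N/NC(N)=S)ccc3n2C2CCCCC2)cc1` is not yet measured and differs from compound 3 by methoxy in place of trifluoromethyl on an aromatic carbon, the same change as that between compound 1 and compound 2, at the same place. Because the earlier change gave a 1.5-fold lower number from compound 1 to compound 2 (0.18 log units; within the scatter), the expected step is a 1.5-fold lower number from compound 3 to compound 4 (0.18 log units; within the scatter), again within the scatter. For compound 4 the expected result in this assay is 20000 nM, most likely between 9000 nM and 45000 nM.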

Compound 4, half-maximal cytotoxic concentration: 39000 nM
Compound 4: middle estimate off by 2.0-fold (0.29 log units), on the low side; the measured number falls inside the stated range.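

In this assay, methoxy in place of trifluoromethyl gives a 1.3-fold higher number from compound 3 to compound 4 (0.11 log units; within the scatter), and this step cannot be told apart from the same change made earlier on the other core: the same change on two cores in this assay, a 1.5-fold lower number (0.18 log units; within the scatter) from compound 1 to compound 2 and a 1.3-fold higher number (0.11 log units; within the scatter) from compound 3 to compound 4, 2.0-fold (0.30 log units) apart, within the scatter of two such steps. The larger group of 7 heavy atoms, put in place of the group of 3, gives a 1.4-fold higher number from compound 2 to compound 4 (0.16 log units; within the scatter), and again the two steps cannot be told apart: the same change on two cores in this assay, a 1.4-fold lower number (0.14 log units; within the scatter) from compound 1 to compound 3 and a 1.4-fold higher number (0.16 log units; within the scatter) from compound 2 to compound 4, 2.0-fold (0.30 log units) apart, within the scatter of two such steps. So neither change shifts the number beyond the scatter on either core, but these small steps do not show that a change carries a fixed size or direction from one core to another.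

As far as these compounds go, whether an amine or a carboxylic acid in place of methoxy would give a step beyond the scatter remains open. So does whether a change that gives such a large step on one core would give the same step on the other.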